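The source may report more compounds than this note shows. Statements on the series, on what has been measured and on what is new or still open speak of the compounds shown alone.

Measured compounds:
compound 1, `COc1ccc(-c2cc(-c3ccc(S(=O)(=O)NC4CC4)cc3)cnc2N)cn1` — 6.3 ug/mL
compound 2, `COc1ccc(-c2cc(-c3ccc4nccn4c3)cnc2N)cn1` — 12.5 ug/mL

Both compounds share one core and differ only in the aryl group attached to it. In a physicochemical assay for solubility, read by nephelometry, in phosphate buffer, measured as kinetic solubility, at pH 6.5 (on this read-out higher numbers stand for higher solubility and lower numbers for lower solubility), compound 1 gives 6.3 ug/mL, and compound 2 gives 12.5 ug/mL. Among the measured compounds shown here, the gap between these two numbers lies within the scatter, so compound 1 and compound 2 cannot be told apart on this read-out; compound 1 is simply the one with the number at the low end of the pair.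

The next compound is compound 3, `COc1ccc(-c2cc(-c3ccc(C(=O)N(C)C)cc3)cnc2N)cn1`. It differs from compound 1 in one place: dimethylcarbamoyl in place of cyclopropylsulfamoyl on an aromatic carbon. For the measured compounds named here, no measured pair in this set shows this exchange, so no step for it is known. From the two numbers available, the expectation for the step from compound 1 to compound 3 is a 2.4-fold higher number from compound 1 to compound 3 (0.38 log units; beyond the scatter), a modest shift upward that may not clear the scatter. Compound 3 is therefore expected to reach about 15 ug/mL in this assay, with a range from 5 ug/mL to 45 ug/mL.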

Compound 3, solubility: > 100 ug/mL
Compound 3 ended at the assay's limit; the forecaster's own chance of this, stated with the estimate: 5%; at least 6.6-fold (0.82 log units) between middle value and limit.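

On the aromatic carbon para to a large group, dimethylcarbamoyl in place of cyclopropylsulfamoyl gives an at least 15-fold higher number from compound 1 to compound 3 (1.20 log units; beyond the scatter) in this assay. This position can therefore move the read-out well beyond the scatter, which compound 1 and compound 2, not separable on this read-out, did not show. Compound 3 gives > 100 ug/mL in this assay, which is a limit of the assay and not a number, so only a lower bound on the size of the step can be read and its true size stays unknown: the limit of > 100 ug/mL in this assay, at which 1 of the 3 values shown sits.

Which part of the exchange carries the step stays open: cyclopropylsulfamoyl leaves together with its three-membered ring and its hydrogen-bond donor, and a dimethylsulfamoyl or a cyclopropylcarbamoyl group on the same aromatic carbon would separate these parts. Equally open, as far as these compounds go, is how an amine or a carboxylic acid at this place would read, and whether any such compound would fall under the limit and so give a real number.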